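The compounds below may be only part of what the source reports. "The series", "measured", "known", "first", "only" and "open" are said of these compounds alone.

Measured so far:
- compound 1, `O=C(O)CCc1ccc(OCc2ncc(-c3cccc(F)c3)o2)cc1`: in a functional assay on CHO cells for agonist activity at Free fatty acid receptor 1 (Homo sapiens), read by FLIPR and calcium flux, in the presence of a further agent that is not named here (on this read-out higher numbers stand for an effect only at larger amounts of compound and lower numbers for an effect already at smaller amounts), compound 1 gives 1070 nM.
- compound 2, `Cc1cccc(-c2noc(COc3ccc(CCC(=O)O)cc3Cl)n2)c1`: in this assay compound 2 gives 4580 nM.

Of the two numbers, compound 2 stands at the higher one; compound 1 is the nearest point, with a lower value, and the gap between them lies beyond the usual scatter. The two structures differ in more than one place, so the gap cannot be assigned to any single change.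

Compound 3, `O=C(O)CCc1ccc(OCc2nc(-c3cccc(C(F)(F)F)c3)no2)c(Cl)c1`, is the next candidate. It differs from compound 2 in one place only: trifluoromethyl in place of methyl on an aromatic carbon. Within the data shown here, no measured pair in the set isolates this exchange, so no step of this kind is known here, and the pair of compound 1 and compound 2 says nothing about it. The expectation is therefore cautious: a step toward a lower number, of moderate size, that may well stay within the scatter.

In this assay compound 3 is estimated at 2500 nM, expected to fall between 800 nM and 8000 nM. The expected step of a 1.8-fold lower number from compound 2 to compound 3 (0.26 log units; within the scatter) is thus modest, with a wide margin on either side.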

Compound 3, half-maximal effective concentration: 30100 nM
Compound 3: middle estimate off by 12-fold (1.08 log units), on the low side; measured number above the stated range.
By their numbers in this assay, from the lowest: compound 1; then compound 2; then compound 3.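

In this assay, the place that carries methyl in compound 2, on an aromatic carbon meta to a large group, proves sensitive to substitution: trifluoromethyl in place of methyl gives a 6.6-fold higher number from compound 2 to compound 3 (0.82 log units; beyond the scatter) and so moves the read-out toward an effect only at larger amounts of compound. Among these compounds, this is the first exchange that can be read at a single place, and it shows that going from one heavy atom to four there is not neutral, even though neither group adds a hydrogen-bond donor, a hydrogen-bond acceptor or a net charge. Nothing at hand bears on what lies behind this step.

From the compounds shown here alone, whether the step is specific to trifluoromethyl or would follow from any group larger than methyl at this place remains open; a hydrogen, a single fluorine, a chlorine or a methoxy group there would help to separate the two readings. Going by these compounds, compound 1 differs from compound 2 and compound 3 in more than one place, so it also remains open whether the same exchange would behave alike on the core of compound 1.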